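Sulfonate ester series: chloro for ethyl on the amide chain

The source may hold more compounds than are shown below. What is called first, only, known or untested is meant among the compounds shown, and "the series" means these compounds.

Within the data shown here, compound 3 `CCCC(=O)Nc1ccc(S(=O)(=O)Oc2ccccc2I)cc1` gives 2000 nM in a functional assay on HT-1080 cells (Homo sapiens) for antiproliferative activity, read by sulforhodamine B assay, with a stated time of 48 h (a higher number here means a weaker inhibitor, a lower number a stronger inhibitor), the lowest of the three numbers measured so far. Compound 1 `CCCC(=O)Nc1cccc(S(=O)(=O)Oc2ccccc2C(C)C)c1` gives 15000 nM and compound 2 `CC(C)c1ccccc1OS(=O)(=O)c1cccc(NC(=O)CCCl)c1` gives 8200 nM, both beyond the scatter from compound 3. Compound 4 `O=C(CCl)Nc1ccc(S(=O)(=O)Oc2ccccc2I)cc1` differs from compound 3 by chloro in place of ethyl on a saturated chain carbon bound to a carbonyl carbon. Among the measured compounds shown here, the only measured step that bears on this change is the one with chloro likewise entering on a saturated chain carbon, a 1.8-fold lower number from compound 1 to compound 2 (0.26 log units; within the scatter), which stayed within the scatter. On that basis compound 4 is expected to stay close to compound 3, with an estimated step of a 1.3-fold lower number from compound 3 to compound 4 (0.12 log units; within the scatter) and nothing beyond the scatter. The estimate for compound 4 is 1500 nM, within a range from 600 nM to 4000 nM.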

Compound 4, half-maximal inhibitory concentration: 600 nM
Compound 4: the middle estimate sits 2.5-fold (0.40 log units) above what was measured; the measured number falls inside the stated range.
By their numbers in this assay, from the lowest: compound 4; then compound 3; then compounds 2 and 1 (each within the scatter of the next).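

On the saturated chain carbon bound to a carbonyl carbon, chloro in place of ethyl gives a 3.3-fold lower number from compound 3 to compound 4 (0.52 log units; beyond the scatter), so this position responds to this change. The earlier chloro step, a 1.8-fold lower number from compound 1 to compound 2 (0.26 log units; within the scatter), lay two bonds along the chain from a carbonyl carbon, on the core of compound 1, and did not show such a shift. No data at hand bear on the reason for the shift.

Open, on these data alone, is whether the chloro itself or the shorter chain carries the step. A plain methyl or a bromomethyl at this place would separate the two.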